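A Bromo-to-Dimethylamino Swap and Its Expected Outcome

The compounds below may be only part of what the source reports. "The series", "measured", "known", "first", "only" and "open" are said of these compounds alone.

Of the compounds shown here, three built on one shared core have so far been tested in an assay for inhibition of beta-glucuronidase (Bos taurus), read by spectrophotometry, with a stated time of 30 min; on this read-out higher numbers stand for weaker inhibition and lower numbers for stronger inhibition. Compound 1 `COC(=O)C1=C(C)NC(=O)NC1c1ccccc1` is reported as "not active" (no number reported) in this assay, with no number given. Compound 2 `COC(=O)C1=C(C)NC(=O)NC1c1ccc(O)c(Cl)c1` gives 27200 nM in this assay. Compound 3 `COC(=O)C1=C(C)NC(=O)NC1c1ccc(Br)cc1` gives 64100 nM in this assay, the higher of the two numbers reported; its nearest neighbour is compound 2, whose number lies lower by a margin beyond the usual scatter.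

Compound 4 `COC(=O)C1=C(C)NC(=O)NC1c1ccc(N(C)C)cc1` has not yet been measured in this assay. It differs from compound 3 in a single place: dimethylamino in place of bromo on an aromatic carbon. Among the measured compounds shown here, no measured pair in this set shows what such a change does, so the direction of the step cannot be read from the data. From the compounds shown here alone, what the data do show is that compound 1, lacking any such group, is not active, while compound 3 with bromo gives 64100 nM; whether dimethylamino behaves like bromo is unknown. Compound 4 is therefore expected to land close to compound 3, and the step from compound 3 to compound 4 is estimated at a 1.2-fold higher number from compound 3 to compound 4 (0.10 log units; within the scatter), not beyond the scatter, with a real chance that only inactivity is reported. Compound 4 is expected at 80000 nM, within a range from 25000 nM to 250000 nM.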

Compound 4, half-maximal inhibitory concentration: 49200 nM
For compound 4 the middle estimate is 1.6-fold (0.21 log units) above the measured one; the range from low to high includes it.
By their numbers in this assay, from the lowest: compounds 2, 4 and 3 (each within the scatter of the next, the first and the last beyond it).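

Putting dimethylamino in place of bromo on this aromatic carbon, para to a large group, gives a 1.3-fold lower number from compound 3 to compound 4 (0.11 log units; within the scatter) in this assay, so on this read-out the two groups cannot be told apart. Among the compounds shown here, this is the first measured step at this place, and it shows that a group with more heavy atoms and a hydrogen-bond acceptor, which bromo lacks, still gives a number there, whereas compound 1, which has neither group, is reported as "not active" (no number reported) in this assay. No independent evidence bears on this result.

For the compounds shown here, whether any group at this aromatic carbon can move the number beyond the scatter remains open, as only two groups have a number here, and a carboxylic acid, a primary amine or a longer alkyl chain in the same place could show how far this tolerance extends. Going by these compounds alone, compound 2 differs from both compound 3 and compound 4 in more than one place, so it gives no clean step for this position, and the separate contributions of its hydroxy and chloro groups also remain unresolved.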